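The source may hold more compounds than are shown below. What is called first, only, known or untested is meant among the compounds shown, and "the series" means these compounds.

Measured so far:
compound 1, `N=C(N)NCCCCN(CC[C@H](N)C(=O)O)C[C@H]1O[C@@H](n2cnc3c(N)ncnc32)[C@H](O)[C@@H]1O`: 49%
compound 2, `C#CCN(CC[C@H](N)C(=O)O)C[C@H]1O[C@@H](n2cnc3c(N)ncnc32)[C@H](O)[C@@H]1O`: 75%

For the measured compounds named here, in an assay on isolated protein for inhibition of histone-lysine N-methyltransferase SETD7 (Homo sapiens), read by scintillation counting, with a stated time of 90 min, tested at 100 uM (a lower number here means less inhibition, a higher number more inhibition at the concentration tested (going by the name of the read-out)), compound 2 stands highest of the two measured compounds; the only step known is a number 26 percentage points higher from compound 1 to compound 2 (beyond the scatter), where a larger nitrogen-containing group gave way to a small two-carbon group on the chain carbon bound to the amine nitrogen.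

Compound 3, `N=C(N)NCCn1cc(CN(CC[C@H](N)C(=O)O)C[C@H]2O[C@@H](n3cnc4c(N)ncnc43)[C@H](O)[C@@H]2O)nn1`, differs from compound 2 by a group of 11 heavy atoms (5 carbon, 6 nitrogen; one five-membered aromatic ring with 3 hetero atoms) in place of a group of 2 heavy atoms (2 carbon; no ring), on a saturated chain carbon bound to an amine nitrogen. The step from compound 1 to compound 2 bears on it, since compound 3 again carries a large nitrogen-rich group at that same place. A drop of similar size is therefore expected, a number 25 percentage points lower from compound 2 to compound 3 (beyond the scatter), and compound 3 is estimated at 50%, likely between 25% and 72%.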

Compound 3, a percentage reported as inhibition, at one concentration (the size of the read-out at that concentration, not a potency): > 50%
Compound 3 gave a limit, no number; the forecaster's own chance of this, stated with the estimate: 0%; the middle value lies on the limit itself.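

Compound 3 gives only a limit, not a number, in this assay: the limit of > 50% in this assay, at which 1 of the 3 values shown sits.

The step that would compare it with compound 2 cannot be read. For the compounds shown here, the one readable comparison is a number at least 1 percentage points higher from compound 1 to compound 3 (that floor lies within the scatter), so this place on a saturated chain carbon bound to an amine nitrogen can carry a group with a five-membered aromatic ring and 11 heavy atoms without the limit ranking it against the smaller group of 7 heavy atoms.

Going by these compounds, the true number for compound 3 stays open, and so does its order against compound 2. Also open, on these data alone, is how a plain amine or a carboxylic acid at this place would read.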